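From ethoxy to an aryl amide on the sulfur chain

The source may hold more compounds than are shown below. What is called first, only, known or untested is meant among the compounds shown, and "the series" means these compounds.

In a functional assay on HCT-116 cells (Homo sapiens) for inhibition, read by MTT assay, with a stated time of 48 h (on this read-out higher numbers stand for weaker inhibition and lower numbers for stronger inhibition), compound 1 `COc1ccc(-n2c(S)nnc2-c2cc(OC)c(OC)c(OC)c2)cc1` gives > 60000 nM, which is a limit and not a number. Compound 3 `CCOC(=O)CSc1nnc(-c2cc(OC)c(OC)c(OC)c2)n1-c1ccc(OC)cc1` gives > 60000 nM, likewise a limit, and so stands at the limit of > 60000 nM in this assay, at which 2 of the 3 values shown sit. Compound 2 `COc1ccc(-n2c(SCc3ccc(F)cc3)nnc2-c2cc(OC)c(OC)c(OC)c2)cc1` gives a true number of 38700 nM.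

Compound 4 `COc1ccc(NC(=O)CSc2nnc(-c3cc(OC)c(OC)c(OC)c3)n2-c2ccc(OC)cc2)cc1` carries (4-methoxyphenyl)amino in place of ethoxy on a carbonyl carbon.

Going by the values given here, two measured steps bear on this change: an at least 1.5-fold lower number from compound 1 to compound 2 (0.19 log units; that floor lies within the scatter) and an at least 1.5-fold higher number from compound 2 to compound 3 (0.19 log units; that floor lies within the scatter). Both rest on a limit, so only their floors can be read. Among the compounds with values here, the one compound giving a number, compound 2 at 38700 nM, has an aromatic ring on the chain, as compound 4 will, but this is a single case. A modest move towards a lower number is therefore expected in this assay, and a second limit remains possible. The expected step is an at least 1.7-fold lower number from compound 3 to compound 4 (0.23 log units; that floor lies within the scatter). For compound 4 the estimated value is 35000 nM, with an expected range from 12000 nM to 60000 nM.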

Compound 4, half-maximal inhibitory concentration: > 60000 nM
Compound 4 gave a limit, no number; the forecaster's own chance of this, stated with the estimate: 40%; middle value at least 1.7-fold (0.23 log units) away from the limit.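

An aromatic ring on the sulfur chain does not by itself bring a true number in this assay: compound 4 carries one and still gives only a limit. Going by these compounds alone, the one readable step is an at least 1.5-fold higher number from compound 2 to compound 4 (0.19 log units; that floor lies within the scatter), while the steps that lead to compound 4 from the two other limit compounds cannot be read. Placing (4-methoxyphenyl)amino in place of ethoxy on a carbonyl carbon therefore leaves the series where most of it already sits: the limit of > 60000 nM in this assay, at which 3 of the 4 values shown sit.

Still open, as far as these compounds go, is whether any group on this carbonyl carbon gives a true number, for instance a carboxylic acid or a small amine such as dimethylamino in place of ethoxy. Also open, from the compounds shown here alone, is whether the true number of compound 2 survives a longer chain between the sulfur and the 4-fluorophenyl ring.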